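From ureido to 4-methylpiperazin-1-yl on a shared core

The compounds below may be only part of what the source reports. "The series", "measured", "known", "first", "only" and "open" are said of these compounds alone.

In a functional assay on RKOp27 cells (Homo sapiens) for cytotoxicity, read by MTT assay, with a stated time of 3 days (a lower number here means a stronger inhibitor, a higher number a weaker inhibitor), compound 1 (`N#Cc1c(Nc2ccccc2)nc(SCc2nc3ccccc3[nH]2)nc1-c1ccccc1`) gives 4.9 nM, and compound 2 (`N#Cc1c(NC(N)=O)nc(SCc2nc3ccccc3[nH]2)nc1-c1ccccc1`) gives 2.5 nM. Among the measured compounds shown here, compound 2 has only this one measured neighbour, and the two cannot be told apart. The step between them is a 2.0-fold lower number from compound 1 to compound 2 (0.29 log units; within the scatter), which lies within the scatter and places carbamoyl in place of phenyl on a nitrogen on an aromatic ring.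

Compound 3 (`CN1CCN(c2nc(SCc3nc4ccccc4[nH]3)nc(-c3ccccc3)c2C#N)CC1`) has 4-methylpiperazin-1-yl in place of ureido on an aromatic carbon, ortho to a cyano group: 4-methylpiperazin-1-yl in place of ureido on an aromatic carbon. For the measured compounds named here, no measured compound carries a non-aromatic ring at this place, so the single available step, a 2.0-fold lower number from compound 1 to compound 2 (0.29 log units; within the scatter), is only a weak guide. It shows two quite different groups giving values within the scatter, which argues against expecting a large shift in this assay. The data do not fix the direction, and a higher number is a cautious expectation for a change this large. The expected step is a 3.2-fold higher number from compound 2 to compound 3 (0.51 log units; beyond the scatter), a modest one. Compound 3 is estimated at 8 nM, with an expected range of 1.5 nM to 45 nM.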

Compound 3, half-maximal inhibitory concentration: 5.4 nM
Compound 3: middle estimate off by 1.5-fold (0.17 log units), on the high side; the range from low to high includes it.
By their numbers in this assay, from the lowest: compounds 2, 1 and 3 (each within the scatter of the next, the first and the last beyond it).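

In this assay, among the compounds shown here, a six-membered non-aromatic ring with 2 hetero atoms is now seen on this aromatic carbon, ortho to a cyano group, and exchanging ureido for 4-methylpiperazin-1-yl gives a 2.2-fold higher number from compound 2 to compound 3 (0.33 log units; beyond the scatter) as the first step at this place to pass beyond the scatter, although it remains modest. For the compounds shown here, the comparison with anilino points the other way, since a 1.1-fold higher number from compound 1 to compound 3 (0.04 log units; within the scatter) shows that 4-methylpiperazin-1-yl and anilino cannot be told apart here, so a large non-aromatic group and an aromatic one sit at the same level, and only the pair of compound 2 and compound 3 is separated at all. The available data offer no measurement that would explain these numbers.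

What remains open is whether the methyl group on the piperazine matters, since a plain piperazin-1-yl does not appear among these compounds, and whether a morpholin-4-yl would stay at the same level. Going by these compounds, it is also open how far this place accepts change, as a carboxylic acid or a longer chain ending in an amine would test a different kind of group on the shared core.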